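Aryl exchange on the shared core: compound 2 to compound 3

This account rests on a few compounds, and the source may have more. Where it says the series, first, only, none or still open, it means among the compounds named here.

In an ADME assay on L02 cells (Homo sapiens) for cytotoxicity, read by MTT assay, with a stated time of 24 h (on this read-out lower numbers stand for stronger inhibition and higher numbers for weaker inhibition), compound 1 (`COc1cc(/C=C2\CN(C)C/C(=C\c3ccccc3F)C2=O)cc(OC)c1OC`) gives 12100 nM and compound 2 (`COc1cc(/C=C2\CN(C)C/C(=C\c3ccc(Cl)cc3Cl)C2=O)cc(OC)c1OC`) gives 13400 nM as its reading. Among the measured compounds shown here, these are the only two numbers so far and they lie within the scatter of each other, so compound 2 is not separated from compound 1.

Compound 3 (`COc1cc(/C=C2\CN(C)C/C(=C\c3cccc([N+](=O)[O-])c3)C2=O)cc(OC)c1OC`) carries 3-nitrophenyl in place of 2,4-dichlorophenyl on a double-bonded chain carbon bound to a double-bonded ring carbon, counted as 3-nitrophenyl in place of 2,4-dichlorophenyl on a double-bonded chain carbon bound to a double-bonded ring carbon for this exchange.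

For the measured compounds named here, one measured step bears on it, at the same place: a 1.1-fold higher number from compound 1 to compound 2 (0.04 log units; within the scatter) is small and stays within the scatter. Going by the values given here, that step exchanges only halogen-bearing groups, and no nitro-bearing compound has been measured, so the support is thin. The expected move in this assay is a 1.1-fold lower number from compound 2 to compound 3 (0.05 log units; within the scatter) and no step beyond the scatter is expected.

For compound 3 the estimated value is 12000 nM with an expected range from 6000 nM to 24000 nM as its span.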

Compound 3, half-maximal inhibitory concentration: 13600 nM
For compound 3 the middle estimate is 1.1-fold (0.05 log units) below the measured one, and the stated range covers the measured number.
By their numbers in this assay, from the lowest: compounds 1, 2 and 3 (each within the scatter of the next).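

In this assay, the range of aryl groups at this place, on a double-bonded chain carbon bound to a double-bonded ring carbon, now extends beyond the halogen-bearing ones, and the exchange for 3-nitrophenyl gives a 1.0-fold higher number from compound 2 to compound 3 (0.01 log units; within the scatter) as its step. Among the compounds shown here, measured against the 2-fluorophenyl compound, the same group gives a 1.1-fold higher number from compound 1 to compound 3 (0.05 log units; within the scatter) as its step, so neither exchange separates compound 3 from the earlier compounds. The 3-nitrophenyl group brings nitrogen, oxygen and 2 hydrogen-bond acceptors where 2,4-dichlorophenyl has none, yet this change in atoms leaves the readings unseparated, and no measured evidence accompanies the result to account for it.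

On these data alone, whether an amine or a carboxylic acid on the aryl ring, or a longer chain in place of that ring, would give a reading beyond the scatter of these three compounds remains open. Also open, as far as these compounds go, is how readings respond to exchanges elsewhere, since the rest of the shared core is the same in all three compounds.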